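The source may report more compounds than this note shows. Statements on the series, on what has been measured and on what is new or still open speak of the compounds shown alone.

Compound 1, `Cc1ccc(CS/C(=C/c2ccccc2F)C(=O)c2ccc(Cl)cc2)cc1`, is measured in a functional assay on DU-145 cells (Homo sapiens) for inhibition, read by trypan blue exclusion, with a stated time of 96 h (a lower number here means a stronger inhibitor of growth, a higher number a weaker inhibitor of growth), where compound 1 gives 10000 nM. Compound 3, `Cc1ccc(CS/C(=C/c2ccc(O)cc2)C(=O)c2ccc(Cl)cc2)cc1`, gives 10000 nM in this assay, and compound 2, `Cc1ccc(CS/C(=C/c2cc([N+](=O)[O-])ccc2F)C(=O)c2ccc(Cl)cc2)cc1`, gives 1000 nM. Compound 1 thus stands level with compound 3 at the digits shown, and the two of them hold the highest numbers of the three; the one step that separates compound 1 from the rest is a 10-fold lower number from compound 1 to compound 2 (1.00 log units; beyond the scatter).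

Compound 4, `Cc1ccc(CS/C(=C/c2ccccc2OCc2ccccc2)C(=O)c2ccc(Cl)cc2)cc1`, differs from compound 1 by benzyloxy in place of fluoro on an aromatic carbon, the benzyloxy sitting ortho to a large group. Within the data shown here, two measured steps bear on changes at this part of the molecule: nitro entering on the same ring gave a 10-fold lower number from compound 1 to compound 2 (1.00 log units; beyond the scatter), while exchanging the ring for a 4-hydroxyphenyl gave no change at the digits printed from compound 1 to compound 3 (within the scatter). A change on this ring can therefore move the number by a modest amount or leave it alone, and the benzyloxy group resembles neither change closely. He expects compound 4 to gain a little, with an expected step of a 2.0-fold lower number from compound 1 to compound 4 (0.30 log units; within the scatter). The estimate for compound 4 in this assay is 5000 nM, within a range from 1000 nM to 20000 nM.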

Compound 4, concentration for 50% growth inhibition: 1000 nM
Beside the measured number, compound 4's estimate is 5.0-fold (0.70 log units) above it; low and high end bracket the measured number.
By their numbers in this assay, from the lowest: compounds 2 and 4 (each within the scatter of the next); then compounds 1 and 3 (each within the scatter of the next).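

The exchange shows that the aromatic carbon carrying fluoro in compound 1 accepts a far larger group, one that brings a second aromatic ring, and that in this assay this gives a 10-fold lower number from compound 1 to compound 4 (1.00 log units; beyond the scatter). Among these compounds, the earlier compounds had changed this ring only by adding nitro with the fluoro kept, which gave a 10-fold lower number from compound 1 to compound 2 (1.00 log units; beyond the scatter), or by replacing the whole ring, so this is the first step read at the fluoro-bearing carbon itself, and it is as large as the nitro step. Nothing measured here explains the gain.

From the compounds shown here alone, it remains open whether the oxygen or the added phenyl ring carries the step, which a methoxy or a longer alkoxy chain at this carbon would help to separate. Going by these compounds, whether benzyloxy and nitro together on this ring would lower the number further also remains open.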